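The source may report more compounds than this note shows. Statements on the series, on what has been measured and on what is new or still open speak of the compounds shown alone.

Measured compounds:
compound 1 `CCN(CC)C(=O)CN(c1cccc(N(C)C)c1C#N)S(=O)(=O)c1ccc(OC)c(OC)c1` gives 110 nM
compound 2 `CCN(CC)C(=O)CN(c1cc2c(C)nsc2cc1Cl)S(=O)(=O)c1ccc(OC)c(OC)c1` gives 4.5 nM

Compound 2 stands at the lowest number of the two in a functional assay on CHO cells for inhibition of Orexin receptor type 2 (Homo sapiens), read by FLIPR and calcium flux (a lower number here means a stronger inhibitor, a higher number a weaker inhibitor), and its nearest neighbour is compound 1 at a much higher number. Going by the values given here, the only measured step, a 24-fold lower number from compound 1 to compound 2 (1.39 log units; beyond the scatter), is large and shows that the group on the sulfonamide nitrogen matters a great deal. Compound 3 `CCN(CC)C(=O)CN(c1cc(C(C)C)ccc1Cl)S(=O)(=O)c1ccc(OC)c(OC)c1` carries a third such group: a group of 10 heavy atoms (9 carbon, 1 chlorine; one six-membered aromatic ring of carbon only) in place of a group of 11 heavy atoms (8 carbon, 1 nitrogen, 1 sulfur, 1 chlorine; one five-membered aromatic ring with 2 hetero atoms, one six-membered aromatic ring of carbon only), on a sulfonamide nitrogen. Since the entering group resembles neither of the measured ones, the step is expected to fall between the two measured numbers, a rise from compound 2 of a 6.7-fold higher number from compound 2 to compound 3 (0.82 log units; beyond the scatter). For compound 3 the estimated value is 30 nM, within 8 nM to 120 nM.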

Compound 3, half-maximal inhibitory concentration: 90 nM
For compound 3 the middle estimate is 3.0-fold (0.48 log units) below the measured one; low and high end bracket the measured number.
By their numbers in this assay, from the lowest: compound 2; then compounds 3 and 1 (each within the scatter of the next).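

Replacing the two-ring group of compound 2 with 2-chloro-5-isopropylphenyl costs much of the potency (a 20-fold higher number from compound 2 to compound 3 (1.30 log units; beyond the scatter)), so a chlorine-bearing group alone does not secure the low number of compound 2. The two single-ring groups, though very different, leave compounds 1 and 3 level (a 1.2-fold lower number from compound 1 to compound 3 (0.09 log units; within the scatter)). Nothing available here explains this gap.

Still open, from the compounds shown here alone, is whether an amine or a methoxy group in place of the isopropyl would change the number. It is also unknown how the step would behave with a carboxylic acid on the ring.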